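Aniline replacing methoxy on the pendant aryl of compound 3

The source may report more compounds than this note shows. Statements on the series, on what has been measured and on what is new or still open speak of the compounds shown alone.

Measured so far:
compound 1 `COc1ccc(-c2cc3ccccc3c(-c3cccc(N)c3)n2)cc1` 2350 nM
compound 2 `COc1ccc(-c2cc3cc(C)ccc3c(-c3cccc(O)c3)n2)cc1OC` 370 nM
compound 3 `COc1cccc(-c2nc(-c3ccc(OC)c(OC)c3)cc3cc(C)ccc23)c1` 1840 nM

In a functional assay on HCT-15 cells (Homo sapiens) for cytotoxicity, read by CCK-8 assay and cell counting, with a stated time of 72 h (a higher number here means a weaker inhibitor, a lower number a stronger inhibitor), compound 3 stands second highest of the three numbers. Its nearest neighbour is compound 1, which sits within the scatter; the furthest is compound 2, which sits beyond it. Going by the values given here, the one single-point step in hand, a 5.0-fold higher number from compound 2 to compound 3 (0.70 log units; beyond the scatter), shows that capping the phenol as a methyl ether raised the number.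

Compound 4 `COc1ccc(-c2cc3cc(C)ccc3c(-c3cccc(N)c3)n2)cc1OC` is the next member. The change from compound 3 is amino in place of methoxy on an aromatic carbon, a donor group entering where an ether left. The step of a 5.0-fold higher number from compound 2 to compound 3 (0.70 log units; beyond the scatter) bears on this only indirectly, since it concerns hydroxyl rather than amino. Compound 1 carries the same amino group but differs from compound 4 in two other places; in this assay compound 1 gives 2350 nM and does not by itself suggest a gain. A modest fall in this assay, short of the full reversal of a 5.0-fold higher number from compound 2 to compound 3 (0.70 log units; beyond the scatter), is the expectation. Compound 4 is therefore expected to give 900 nM, with a range from 300 nM to 2800 nM, which means an expected step of a 2.0-fold lower number from compound 3 to compound 4 (0.31 log units; beyond the scatter).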

Compound 4, half-maximal inhibitory concentration: 2700 nM
For compound 4 the middle estimate is 3.0-fold (0.48 log units) below the measured one; the range from low to high includes it.
By their numbers in this assay, from the lowest: compound 2; then compounds 3, 1 and 4 (each within the scatter of the next).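

In this assay, the move from 3-methoxyphenyl to 3-aminophenyl gives a 1.5-fold higher number from compound 3 to compound 4 (0.17 log units; within the scatter) even though amino enters with 1 hydrogen-bond donor and methoxy leaves with 0 hydrogen-bond donors, so at this position the count of donors alone does not separate these two compounds. Hydroxy is now set apart from two replacements on this aromatic carbon, not one: alongside a 5.0-fold higher number from compound 2 to compound 3 (0.70 log units; beyond the scatter) stands a 7.3-fold higher number from compound 2 to compound 4 (0.86 log units; beyond the scatter), while the methoxy and amino compounds cannot be told apart. No measurement in hand explains why hydroxy differs from the other two groups.

As far as these compounds go, whether a carboxylic acid or an acetamide on this carbon would fall with hydroxy or with methoxy and amino remains open. Compound 1 differs from compound 4 in more than one place, so the separate steps for the core methyl and the second methoxy cannot be read.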